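This account rests on a few compounds, and the source may have more. Where it says the series, first, only, none or still open, it means among the compounds named here.

Among the measured compounds shown here, compound 2 `CN(C(=O)c1ccccc1)c1ccc2[nH]c(-c3n[nH]c4ccccc34)cc2n1` is one of two compounds so far tested in a functional assay on HL-60 cells (Homo sapiens) for antiproliferative activity, read by MTT assay, with a stated time of 72 h; a lower number here means a stronger inhibitor, a higher number a weaker inhibitor. In that assay compound 2 gives 4850 nM, and compound 1 `CN(C(=O)C(C)(C)C)c1ccc2[nH]c(-c3n[nH]c4ccccc34)cc2n1` gives 4990 nM. The step of a 1.0-fold lower number from compound 1 to compound 2 (0.01 log units; within the scatter) shows that exchanging the group on the carbonyl carbon left the number essentially unchanged, so on the numbers shown compound 2 cannot be set apart from compound 1. Compound 3 `CN(C(=O)c1ccc(F)cc1)c1ccc2[nH]c(-c3n[nH]c4ccccc34)cc2n1` differs from compound 2 by fluoro in place of hydrogen on an aromatic carbon. No measured step touches the aromatic ring of the benzoyl group itself; the only step shown, from compound 1 to compound 2, replaced that whole ring and was within the scatter. On that basis compound 3 is expected to move by no more than the scatter, with the step of a 1.1-fold lower number from compound 2 to compound 3 (0.03 log units; within the scatter) taken as the best guess. Compound 3 is therefore estimated at 4500 nM in this assay, with a range from 1500 nM to 14000 nM.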

Compound 3, half-maximal inhibitory concentration: 1210 nM
Compound 3: the middle estimate sits 3.7-fold (0.57 log units) above what was measured, and the stated range ends above it.
By their numbers in this assay, from the lowest: compound 3; then compounds 2 and 1 (each within the scatter of the next).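

In this assay, the benzoyl ring turns out to respond to a single atom: fluoro in place of hydrogen, on an aromatic carbon para to a large group, gives a 4.0-fold lower number from compound 2 to compound 3 (0.60 log units; beyond the scatter), a modest step. The earlier exchange of tert-butyl for phenyl had shown no separation between the compounds, whereas 4-fluorophenyl in place of tert-butyl gives a 4.1-fold lower number from compound 1 to compound 3 (0.62 log units; beyond the scatter), so among these three compounds the carbonyl substituents differ only once fluoro is present. Nothing available accounts for this gain.

As far as these compounds go, it remains open whether the gain is particular to fluoro or would also appear with chloro, methoxy or a nitrile on the same carbon. Also open, from the compounds shown here alone, is whether fluoro on another carbon of that ring would produce a similar step.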